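Working notes on a cytotoxicity series before a chain extension

A few compounds are considered here, and "the series" means these few. Any claim that something is new, unique, unknown or untested is made for them only; others in the source may bear on it.

Measured compounds:
- compound 1 `COc1cccc2cc(-c3ccccc3)c(O)nc12` — 10000 nM
- compound 2 `COc1cc(OC)c2cc(-c3ccccc3)c(O)nc2c1` — 10000 nM
- compound 3 `COc1ccc(-c2cc3c(OC)cc(OC)cc3n(C)c2=O)cc1` — 10000 nM

All three were read in a functional assay on MCF7 cells (Homo sapiens) for cytotoxicity, read by colorimetric assay and MTT assay; on this read-out lower numbers stand for stronger inhibition and higher numbers for weaker inhibition. On the numbers shown, compound 3 stands level with compound 1 and compound 2 at the digits given; against compound 1 there is no change at the digits given, and against compound 2 likewise none, both within the scatter. For the measured compounds named here, no pair of measured compounds differs in only one place, so no step between measured compounds is available, and nothing can be said about which part of the shared core carries the activity beyond the fact that all three values sit together.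

The next compound, compound 4 `COC(=O)CCn1c(=O)c(-c2ccc(OC)cc2)cc2c(OC)cc(OC)cc21`, differs from compound 3 in one place: (methoxycarbonyl)methyl in place of hydrogen on a saturated chain carbon bound to an aromatic nitrogen.

In the absence of any recorded step, the expectation for this change rests on the flat picture among compound 1, compound 2 and compound 3. For compound 4 the step from compound 3 is expected to stay within the scatter, with no direction beyond it, as no change at the digits printed from compound 3 to compound 4 (within the scatter). In this assay compound 4 is accordingly estimated at 10000 nM, with a range from 4000 nM to 25000 nM.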

Compound 4, half-maximal inhibitory concentration: 10000 nM
Estimate against measurement, compound 4: no gap at the digits printed; the range from low to high includes it.
By their numbers in this assay, from the lowest: compounds 1, 2, 3 and 4 (each within the scatter of the next).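

In this assay the series now has its first readable step: (methoxycarbonyl)methyl in place of hydrogen on a saturated chain carbon bound to an aromatic nitrogen gives no change at the digits printed from compound 3 to compound 4 (within the scatter) in this comparison. Compounds 1, 2 and 3 sat together but offered no single-place comparison, whereas this step ties the flat reading to one position and one change: the methyl becomes a 2-(methoxycarbonyl)ethyl, adding 5 heavy atoms and 2 hydrogen-bond acceptors with no shift in the printed value. The data shown contain no separate measurement that bears on this result.

Still open, as far as these compounds go, is whether a carboxylic acid in place of the methoxycarbonyl end, an amine on the chain, or a longer chain at this same place would also leave the reading in this assay unchanged. For the compounds shown here, also open is whether the same (methoxycarbonyl)methyl change would read the same way on the core of compound 1 or compound 2, since the one step available stands on the core of compound 3 alone.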